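Removing One Methoxy Group from a Weak Growth Inhibitor

The source may hold more compounds than are shown below. What is called first, only, known or untested is meant among the compounds shown, and "the series" means these compounds.

Compound 1 `Nc1cc(N)c2nc(-c3ccccc3)c(NCc3ccc(Cl)c(Cl)c3)nc2c1` gives 55000 nM in a functional assay on T47D cells (Homo sapiens) for inhibition, read by sulforhodamine B assay, with a stated time of 48 h; a lower number here means a stronger inhibitor of growth, a higher number a weaker inhibitor of growth. Compound 2 `COc1ccc(CNc2nc3cc(N)cc(N)c3nc2-c2ccccc2)cc1OC` in this assay shows only a limit of the assay, < 100000 nM, as the limit of < 100000 nM in this assay, at which 1 of the 2 values shown sits, records. The step that the limit leaves unreadable from compound 1 to compound 2 therefore cannot be read in size. Compound 3 `COc1ccc(CNc2nc3cc(N)cc(N)c3nc2-c2ccccc2)cc1` differs from compound 2 by hydrogen in place of methoxy on an aromatic carbon. No measured step bears on this change, and the only step shown is unreadable, so in this assay no direction can be expected beyond the scatter. Compound 3 is therefore estimated at 60000 nM, ranging from 20000 nM to 150000 nM, a step that the limit leaves unreadable from compound 2 to compound 3 that is expected to be small.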

Compound 3, concentration for total growth inhibition: 11000 nM
Compound 3: middle estimate off by 5.5-fold (0.74 log units), on the high side; the measured number lies below the stated range.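

Within the data shown here, in this series, swapping 3,4-dichlorophenyl for 4-methoxyphenyl gives the first step that can be read, a 5.0-fold lower number from compound 1 to compound 3 (0.70 log units; beyond the scatter), so growth inhibition does respond to a change in this part of the molecule. The steps involving compound 2 cannot be read, so the effect of removing the methoxy group alone has no size, because compound 2 carries only a limit: the limit of < 100000 nM in this assay, at which 1 of the 3 values shown sits.

On these data alone, whether an amine or a carboxylic acid in place of that methoxy group would lower the number further remains open. So does the effect of a longer chain between the aromatic ring and the nitrogen.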